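The compounds below may be only part of what the source reports. "The series", "measured", "known", "first", "only" and "open" are said of these compounds alone.

Measured so far in a functional assay on MCF7 cells (Homo sapiens) for inhibition, read by MTT assay, with a stated time of 72 h; a lower number here means a stronger inhibitor, a higher number a weaker inhibitor:
compound 1, `CC(C)c1ccc(-c2nc(SCc3cn(CC(=O)NC(=O)Nc4ccccn4)nn3)nc(Nc3cccc(C(F)(F)F)c3)c2C#N)cc1`, 8620 nM;
compound 2, `COc1cc(-c2nc(SCc3cn(CC(=O)NC(=O)Nc4ccccn4)nn3)nc(Nc3ccc(C(C)C)cc3)c2C#N)cc(OC)c1OC`, 30900 nM;
compound 3, `COc1cc(-c2nc(SCc3cn(CC(=O)NC(=O)Nc4ccccn4)nn3)nc(Nc3ccc(C)cc3)c2C#N)cc(OC)c1OC`, 21000 nM.

Compound 3 stands second highest of the three numbers in this assay. Its nearest neighbour is compound 2, whose number is higher by an amount within the scatter; its furthest is compound 1, whose number lies lower by an amount beyond the scatter. Among the measured compounds shown here, the only single-site step among the measured compounds, a 1.5-fold lower number from compound 2 to compound 3 (0.17 log units; within the scatter), concerns a methyl in place of an isopropyl and does not touch the change now considered.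

Compound 4, `COc1cc(-c2nc(SCc3cn(CC(=O)NC(=O)Nc4ccccn4)nn3)nc(Nc3cccc(C(F)(F)F)c3)c2C#N)cc(OC)c1OC`, differs from compound 3 by 3-(trifluoromethyl)phenyl in place of 4-methylphenyl on a nitrogen on an aromatic ring. For the measured compounds named here, no measured step bears directly on this change. Compound 1 carries the same 3-(trifluoromethyl)phenyl group but differs from compound 3 elsewhere too, so its lower value is only a loose pointer. Compound 4 is therefore expected to give a somewhat lower number, a step of a 1.5-fold lower number from compound 3 to compound 4 (0.18 log units; within the scatter), with its estimate in this assay at 14000 nM, ranging from 6000 nM to 35000 nM.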

Compound 4, half-maximal inhibitory concentration: 8140 nM
Estimate against measurement, compound 4: 1.7-fold (0.24 log units) above; low and high end bracket the measured number.
By their numbers in this assay, from the lowest: compounds 4 and 1 (each within the scatter of the next); then compounds 3 and 2 (each within the scatter of the next).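

In this assay, the nitrogen-linked aryl group proves able to move the number beyond the scatter: 3-(trifluoromethyl)phenyl in place of 4-methylphenyl gives a 2.6-fold lower number from compound 3 to compound 4 (0.41 log units; beyond the scatter) and in place of 4-isopropylphenyl gives a 3.8-fold lower number from compound 2 to compound 4 (0.58 log units; beyond the scatter), whereas the earlier methyl-for-isopropyl step at this site stayed within the scatter. With 3-(trifluoromethyl)phenyl held fixed, 3,4,5-trimethoxyphenyl in place of 4-isopropylphenyl on an aromatic carbon gives only a 1.1-fold lower number from compound 1 to compound 4 (0.02 log units; within the scatter), so that change does not separate the two compounds. Nothing at hand gives a reason for these steps.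

The compounds shown change the substituent and its place on the phenyl ring together, so the contribution of each stays open. Also open, from the compounds shown here alone, is whether a chloro group or a dimethylamino group on that ring would give a similar step.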